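The compounds below may be only part of what the source reports. "The series", "measured", "known", "first", "only" and "open" are said of these compounds alone.

Compound 1 `Oc1ccc(CNCCCNCc2ccc(O)c3ncccc23)c2cccnc12`, compound 2 `Oc1ccc(CNCc2ccc(CNCc3ccc(O)c4ncccc34)cc2)c2cccnc12` and compound 3 `Oc1ccc(CN2CCCNCCNCCCNCC2)c2cccnc12` have been run in an ADME assay on PBMC cells (Homo sapiens) for cytotoxicity; on this read-out higher numbers stand for lower toxicity in this test and lower numbers for higher toxicity in this test. For compound 1 the read-out is only a limit of the assay, > 10000 nM. For compound 2 the read-out is likewise a limit, > 10000 nM. Compound 3 also reaches only a limit, > 10000 nM. Compound 3 thus stands at the limit of > 10000 nM in this assay, at which 3 of the 3 values shown sit, no number being known for it. Compound 4 `Oc1ccc(CN2CCCN(Cc3ccc(O)c4ncccc34)CCNCCCNCC2)c2cccnc12` has not yet been measured in this assay. It differs from compound 3 by (8-hydroxyquinolin-5-yl)methyl in place of hydrogen on an amine nitrogen in a ring. Within the data shown here, no measured step between compounds exists here. Because compound 3 sits at the limit of > 10000 nM in this assay, at which 3 of the 3 values shown sit, the step of an at least 1.2-fold lower number from compound 3 to compound 4 (0.09 log units; that floor lies within the scatter) is expected to be none beyond the scatter. Compound 4 is therefore estimated at 8000 nM, with a range from 2500 nM to 25000 nM.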

Compound 4, half-maximal cytotoxic concentration: 8000 nM
Beside the measured number, compound 4's estimate shows no gap at the digits printed; the measured number falls inside the stated range.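

In this assay, putting (8-hydroxyquinolin-5-yl)methyl in place of hydrogen on an amine nitrogen in a ring gives an at least 1.2-fold lower number from compound 3 to compound 4 (0.09 log units; that floor lies within the scatter). Among these compounds, compound 4 thus gives the first actual number, although the true size of the step cannot be read. Every other compound shown reaches only a limit of the assay: the limit of > 10000 nM in this assay, at which 3 of the 4 values shown sit.

On these data alone, it remains open whether a smaller group on this nitrogen, such as methyl or benzyl, would also bring the value within the measurable range. As far as these compounds go, it is equally open whether a second (8-hydroxyquinolin-5-yl)methyl group placed on another ring nitrogen would do so.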